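Rearranging Three Fluorines on a Phenyl Group

The source may hold more compounds than are shown below. What is called first, only, known or untested is meant among the compounds shown, and "the series" means these compounds.

Among the measured compounds shown here, in a functional assay on Jurkat cells (Homo sapiens) (a lower number here means a stronger inhibitor, a higher number a weaker inhibitor), compound 3 `CC(C)[C@H](NC(=O)COc1cccc2ccccc12)C(=O)N[C@@H](CC(=O)O)C(=O)COc1c(F)ccc(F)c1F` gives 1200 nM, the only true number in this small set. Compound 1 `CC(C)[C@H](NC(=O)COc1cccc2ccccc12)C(=O)N[C@@H](CC(=O)O)C(=O)COc1ccc(C(F)(F)F)cc1` gives > 100000 nM, which is a limit of the assay. Compound 2 `CC(C)[C@H](NC(=O)COc1cccc2ccccc12)C(=O)N[C@@H](CC(=O)O)C(=O)COc1ccc(C#N)cc1` gives > 100000 nM, also a limit. Compound 4 `CC(C)[C@H](NC(=O)COc1cccc2ccccc12)C(=O)N[C@@H](CC(=O)O)C(=O)COc1cc(F)c(F)cc1F` has the same atoms as compound 3, joined differently: 2,4,5-trifluorophenyl in place of 2,3,6-trifluorophenyl on an oxygen on a saturated carbon. The closest measured steps are large, an at least 83-fold lower number from compound 1 to compound 3 (1.92 log units; beyond the scatter) and an at least 83-fold lower number from compound 2 to compound 3 (1.92 log units; beyond the scatter), and show that the group on this oxygen can matter greatly. Neither step compares two trifluorophenyl groups, so their size is only a loose guide. The expected change is modest, toward a weaker inhibitor, a 2.5-fold higher number from compound 3 to compound 4 (0.40 log units; beyond the scatter). For compound 4 the estimated value is 3000 nM, with an expected range of 600 nM to 30000 nM.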

Compound 4, half-maximal inhibitory concentration: 39300 nM
For compound 4 the middle estimate is 13-fold (1.12 log units) below the measured one; the whole stated range lies below it.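

With the same atoms on the same oxygen, rearranging the fluorines alone gives a 33-fold higher number from compound 3 to compound 4 (1.52 log units; beyond the scatter), so here their arrangement matters, not just their presence. Compound 4 still sits on the stronger side of the two compounds without ring fluorines, with an at least 2.5-fold lower number from compound 2 to compound 4 (0.40 log units; beyond the scatter) and an at least 2.5-fold lower number from compound 1 to compound 4 (0.40 log units; beyond the scatter) as the steps. Those two steps give only a minimum size: the limit of > 100000 nM in this assay, at which 2 of the 4 values shown sit. With just two trifluorophenyl arrangements shown, it remains open which fluorine accounts for the difference. Going by these compounds, how a plain phenyl or a pentafluorophenyl group would compare also remains open.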